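From 4-nitrobenzyl to 3-(trifluoromethyl)benzyl on compound 3

A few compounds are considered here, and "the series" means these few. Any claim that something is new, unique, unknown or untested is made for them only; others in the source may bear on it.

Compound 1 `COc1ccc2c(=O)c(-c3cc(OC)c(OC)cc3OC)coc2c1` gives 5200 nM in a functional assay on B16 cells (Mus musculus) for antiproliferative activity, read by MTT assay, with a stated time of 24 h; a lower number here means a stronger inhibitor, a higher number a weaker inhibitor.
Compound 2 `COc1cc(OC)c(-c2coc3cc(OCC(=O)c4cccc(C(F)(F)F)c4)ccc3c2=O)cc1OC` reaches only the limit > 10000 nM in this assay.
Compound 3 `COc1cc(OC)c(-c2coc3cc(OCc4ccc([N+](=O)[O-])cc4)ccc3c2=O)cc1OC` reaches only the limit > 10000 nM in this assay.

Compound 3 therefore stands at a limit rather than at a number: it sits at the limit of > 10000 nM in this assay, at which 2 of the 3 values shown sit, so all that is known is that it is a weaker inhibitor than that boundary. Compound 4 `COc1cc(OC)c(-c2coc3cc(OCc4cccc(C(F)(F)F)c4)ccc3c2=O)cc1OC` changes one group at the ether chain: 3-(trifluoromethyl)phenyl in place of 4-nitrophenyl on a saturated chain carbon bound to an oxygen on an aromatic ring.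

For the measured compounds named here, two measured steps bear on this. From the shared core without the ether chain, adding either substituted chain took the value out of range: an at least 1.9-fold higher number from compound 1 to compound 2 (0.28 log units; that floor lies within the scatter) and an at least 1.9-fold higher number from compound 1 to compound 3 (0.28 log units; that floor lies within the scatter). The direct comparison between the two substituted compounds gives a step that the two limits leave unreadable from compound 2 to compound 3, since both ends are limits. Compound 2 already carries a 3-(trifluoromethyl)phenyl group on this chain carbon, though through a carbonyl, and it sits at the limit.

The step that the limit leaves unreadable from compound 3 to compound 4 is therefore expected to be none beyond the scatter, with compound 4 most likely again reported as a limit. Compound 4 is estimated at 15000 nM, between 5000 nM and 50000 nM.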

Compound 4, half-maximal inhibitory concentration: > 10000 nM
Compound 4: no number, only a limit (the forecaster's own chance of this, stated with the estimate: 70%); the middle value does not contradict the limit.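

Compound 4 is a third compound with a substituent on this ether chain, and it carries neither the 4-nitrophenyl of compound 3 nor the carbonyl of compound 2, so neither feature is required for a result beyond the measured range in this assay; all three substituted compounds now share one outcome: the limit of > 10000 nM in this assay, at which 3 of the 4 values shown sit. Measured against the shared core of compound 1, the change gives an at least 1.9-fold higher number from compound 1 to compound 4 (0.28 log units; that floor lies within the scatter), so this third case, like the first two, does not establish a loss of activity beyond the scatter. The steps linking compound 4 to compound 2 and to compound 3 cannot be read, as each has a limit at both ends.

Going by these compounds, how far past the limit each of these three compounds lies remains unknown, so the 4-nitrobenzyl, the 3-(trifluoromethyl)benzyl and the carbonyl-bearing chain cannot be ranked against one another. Also open, on these data alone, is whether a carboxylic acid or an amine on this chain carbon would give a measured number in this assay rather than another limit.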